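Swapping the aryl group on the amide of compound 2

The compounds below may be only part of what the source reports. "The series", "measured", "known", "first", "only" and "open" are said of these compounds alone.

Measured compounds:
compound 1 `CN1[C@@H]2c3[nH]c4ccccc4c3C[C@H]1[C@H](C#N)N1[C@@H](CN3C(=O)c4ccccc4C3=O)c3[nH]c4ccccc4c3C[C@@H]21` gives 20 nM
compound 2 `CN1[C@@H]2c3[nH]c4ccccc4c3C[C@H]1[C@H](C#N)N1[C@@H](CNC(=O)c3cccc(C(F)(F)F)c3)c3[nH]c4ccccc4c3C[C@@H]21` gives 340 nM
compound 3 `COc1ccc(C(=O)NC[C@H]2c3[nH]c4ccccc4c3C[C@H]3[C@H]4c5[nH]c6ccccc6c5C[C@@H]([C@H](C#N)N23)N4C)cc1` gives 310 nM

All three share one core and were tested in a functional assay on HepG2 cells (Homo sapiens) for cytotoxicity, read by MTT assay, with a stated time of 72 h; a higher number here means a weaker inhibitor, a lower number a stronger inhibitor. Compound 2 has the highest number of the three: its nearest neighbour is compound 3, whose number is within the scatter of that of compound 2, while compound 1 lies far off, as shown by a 16-fold higher number from compound 1 to compound 3 (1.19 log units; beyond the scatter), a step that exchanges the whole group on the saturated chain carbon.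

Compound 4 `CN1[C@@H]2c3[nH]c4ccccc4c3C[C@H]1[C@H](C#N)N1[C@@H](CNC(=O)c3ccc(F)cc3)c3[nH]c4ccccc4c3C[C@@H]21` is the next compound. Relative to compound 2 the change is 4-fluorophenyl in place of 3-(trifluoromethyl)phenyl on a carbonyl carbon. Among the measured compounds shown here, one measured step bears on this: the exchange of the aryl group on the carbonyl carbon, a 1.1-fold lower number from compound 2 to compound 3 (0.04 log units; within the scatter), which stayed within the scatter. No other aryl variation at that carbonyl has been measured. The step from compound 2 to compound 4 is therefore expected to stay within the scatter, a 1.1-fold lower number from compound 2 to compound 4 (0.03 log units; within the scatter). Compound 4 is estimated at 320 nM, in the range 150 nM to 700 nM.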

Compound 4, half-maximal inhibitory concentration: 210 nM
The estimate for compound 4 lay 1.5-fold (0.18 log units) above the measured number, within the range that was stated.
By their numbers in this assay, from the lowest: compound 1; then compounds 4, 3 and 2 (each within the scatter of the next).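

With a third aryl group on the carbonyl carbon, this position still shows no measurable preference in this assay: the new 4-fluorophenyl amide gives a 1.6-fold lower number from compound 2 to compound 4 (0.21 log units; within the scatter) and a 1.5-fold lower number from compound 3 to compound 4 (0.17 log units; within the scatter), so it cannot be told apart from either the 3-(trifluoromethyl)phenyl or the 4-methoxyphenyl amide. Among the compounds shown here, the large gap to the group of compound 1 also holds with this new amide (an 11-fold higher number from compound 1 to compound 4 (1.02 log units; beyond the scatter)), so that gap is not peculiar to the single aryl group of compound 3. No accompanying evidence explains either the flat aryl series or this gap.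

From the compounds shown here alone, it remains open whether a simple alkyl chain in place of the aryl group would stay in the same range. Equally open, going by these compounds, is whether an aryl group carrying an amine or a carboxylic acid would do so.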